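The compounds below may be only part of what the source reports. "The series", "measured", "known", "first", "only" and "open" are said of these compounds alone.

Measured compounds:
compound 1 `CCc1cccc2c(=O)c(-c3nn[nH]n3)c[nH]c12` — > 25 mg/kg
compound 2 `O=c1c(-c2nn[nH]n2)c[nH]c2ccc(Cl)cc12` — > 25 mg/kg

In a functional assay on the whole organism (strain Sprague-Dawley) for inhibition, with Rattus norvegicus as the target (a lower number here means that less compound is needed, a higher number that more compound is needed for the effect), compound 1 gives > 25 mg/kg, which is a limit of the assay rather than a number. Compound 2, in this assay, likewise gives > 25 mg/kg, again a limit and not a number. So compound 1 stands at the limit of > 25 mg/kg in this assay, at which 2 of the 2 values shown sit, and nothing more exact is known of it. Among the compounds with values here, no step between two measured compounds is available here, as the two compounds differ in more than one place.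

Compound 3 `CC(C)c1cccc2c(=O)c(-c3nn[nH]n3)c[nH]c12` has not yet been measured. It differs from compound 1 by methyl in place of hydrogen on a saturated chain carbon bound to an aromatic carbon and a saturated chain carbon. Because compound 1 sits at the limit of > 25 mg/kg in this assay, at which 2 of the 2 values shown sit, the step from compound 1 to compound 3 cannot be read against any number, only against a limit. A change of this kind is expected to move the result by no more than the usual scatter, so the step from compound 1 to compound 3 in this assay is expected to be a step that the limit leaves unreadable from compound 1 to compound 3, that is, none beyond the scatter. Compound 3 is therefore expected to give 40 mg/kg in this assay, within a range of 15 mg/kg to 110 mg/kg, and it is likely that only a limit will again be reported.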

Compound 3, minimum effective dose: 10 mg/kg
Compound 3: middle estimate off by 4.0-fold (0.60 log units), on the high side; the whole stated range lies above it.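

In this assay, compound 3 gives 10 mg/kg, the only actual number among the compounds shown, and the change from ethyl to isopropyl amounts to an at least 2.5-fold lower number from compound 1 to compound 3 (0.39 log units; beyond the scatter). Going by these compounds, compound 1 gives > 25 mg/kg, which is a limit of the assay and not a number, so this step marks only the smallest change that fits the data, and its true size stays unknown. Even so, it shows that the group at this place matters, since a single methyl in place of hydrogen on this saturated chain carbon is enough to bring a compound off the limit, where the other compounds shown remain: the limit of > 25 mg/kg in this assay, at which 2 of the 3 values shown sit.

On these data alone, whether the effect keeps growing with a bulkier group such as tert-butyl, holds with a ring such as cyclopropyl, or is also reached by a longer chain such as propyl remains open. With only this one pair to compare, the compounds shown also cannot say why the added methyl makes a difference, or whether the same change would have any effect elsewhere on the shared core.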